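The source may hold more compounds than are shown below. What is called first, only, known or untested is meant among the compounds shown, and "the series" means these compounds.

Measured compounds in a functional assay (HSMC cells, Homo sapiens) for antiproliferative activity, with a stated time of 72 h; on this read-out lower numbers stand for stronger inhibition and higher numbers for weaker inhibition:
compound 1 `COC(=O)[C@H](CCSC)NC(=O)c1ccc(OC[C@H]2COc3ccccc3O2)cc1-c1ccccc1C` gives 6600 nM
compound 2 `COC(=O)[C@H](CCSC)NC(=O)c1ccc(OC[C@@H]2COc3ccccc3O2)cc1-c1ccccc1C` gives 193000 nM
compound 3 `COC(=O)[C@H](CCSC)NC(=O)c1ccc(OC[C@H]2COc3ccccc3O2)cc1-c1ccccc1OC` gives 230000 nM

Compound 1 stands at the lowest of the three numbers in this assay. Its nearest neighbour is compound 2, with a 29-fold higher number from compound 1 to compound 2 (1.47 log units; beyond the scatter); its furthest is compound 3, with a 35-fold higher number from compound 1 to compound 3 (1.54 log units; beyond the scatter). The step from compound 1 to compound 2 rests on (the fact that compounds 1 and 2 differ only in the configuration as drawn).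

Compound 4 `COC(=O)CNC(=O)c1ccc(OC[C@H]2COc3ccccc3O2)cc1-c1ccccc1C` has not yet been measured. Against compound 1 the change is hydrogen in place of 2-(methylsulfanyl)ethyl on a saturated chain carbon bound to an amide-type nitrogen and a carbonyl carbon. Neither measured step touches this part of the molecule: one alters the configuration at a saturated ring carbon, the other swaps the substituent on an aromatic carbon. Both were large losses, but neither gives a direct reading on the chain at the amide-bearing carbon, so the direction here is taken from the removal of a whole side chain rather than from a close precedent. A loss beyond the scatter, though a smaller one than either other step, is expected for compound 4, and the expected step is a 4.5-fold higher number from compound 1 to compound 4 (0.66 log units; beyond the scatter). Compound 4 is estimated at 30000 nM, range 6000 nM to 150000 nM.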

Compound 4, half-maximal inhibitory concentration: 27000 nM
Compound 4: middle estimate off by 1.1-fold (0.05 log units), on the high side; low and high end bracket the measured number.
By their numbers in this assay, from the lowest: compound 1; then compound 4; then compounds 2 and 3 (each within the scatter of the next).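

In this assay the 2-(methylsulfanyl)ethyl group on the saturated chain carbon bound to an amide-type nitrogen and a carbonyl carbon gets its first reading, as replacing it with hydrogen gives a loss beyond the scatter (a 4.1-fold higher number from compound 1 to compound 4 (0.61 log units; beyond the scatter)). The side chain therefore contributes to the activity of compound 1, but this modest step is the smallest seen so far from compound 1, and compound 4 still gives a finite number without the side chain. Nothing available explains this loss.

The compounds shown do not separate the contribution of the sulfur from that of the chain length, which a methyl, an n-butyl or a longer chain at this carbon would address. Also open, going by these compounds, is whether the opposite configuration at this carbon, or a carboxylic acid in place of the methyl ester, would change the number.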